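Furan-carboxylic acids and anilides on colon cells

This account rests on a few compounds, and the source may have more. Where it says the series, first, only, none or still open, it means among the compounds named here.

Of the compounds shown here, three share a core and have been tested in a functional assay on SW480 cells (Homo sapiens) for cytotoxicity, read by MTT assay, with a stated time of 24 h; a higher number here means a weaker inhibitor, a lower number a stronger inhibitor. Compound 1 `C=CC1=C(C(=O)O)C(c2ccc(OC)cc2)OC1` carries a free acid; compound 2 `C=CC1=C(C(=O)Nc2ccccc2)C(c2ccc(OC)cc2)OC1` differs by anilino in place of hydroxy on a carbonyl carbon. In this assay compound 1 reaches only the limit > 100000 nM. In this assay compound 2 likewise reaches only the limit > 100000 nM. The step that the two limits leave unreadable from compound 1 to compound 2 therefore stays unreadable. Compound 3 `C=CC1=C(C(=O)O)C(c2ccc(OC)c(OC)c2)OC1` differs from compound 1 by methoxy in place of hydrogen on an aromatic carbon; in this assay compound 3 also gives only the limit > 100000 nM, so a step that the two limits leave unreadable from compound 1 to compound 3 is unreadable too; all three values sit at the limit of > 100000 nM in this assay, at which 3 of the 3 values shown sit. Compound 4 `C=CC1=C(C(=O)Nc2ccccc2)C(c2ccc(OC)c(OC)c2)OC1` is not yet measured and differs from compound 3 by anilino in place of hydroxy on a carbonyl carbon, the same change as from compound 1 to compound 2. Since that change left compound 2 at > 100000 nM, the step that the limit leaves unreadable from compound 3 to compound 4 is expected to be small. Compound 4 is estimated at 150000 nM, between 60000 nM and 400000 nM.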

Compound 4, half-maximal inhibitory concentration: 45100 nM
Compound 4: middle estimate off by 3.3-fold (0.52 log units), on the high side; measured number below the stated range.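

In this assay, anilino in place of hydroxy on a carbonyl carbon gives an at least 2.2-fold lower number from compound 3 to compound 4 (0.34 log units; beyond the scatter), and methoxy in place of hydrogen on an aromatic carbon gives an at least 2.2-fold lower number from compound 2 to compound 4 (0.34 log units; beyond the scatter). The anilino change therefore lowers the number on the core of compound 3, though only a minimum size can be stated. These notes do not show that the change carries over to the core of compound 1, where its step, like the methoxy step on the free acid, cannot be read, as both ends are limits: the limit of > 100000 nM in this assay, at which 3 of the 4 values shown sit.

As far as these compounds go, the full size of both new steps remains open. A benzylamino or morpholino group in place of the anilino, or a methyl ester in place of the acid, would test whether the lower number requires the anilino group itself.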